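A few compounds are considered here, and "the series" means these few. Any claim that something is new, unique, unknown or untested is made for them only; others in the source may bear on it.

Measured in an ADME assay on HEK293 cells (Homo sapiens) for cytotoxicity, read by MTT assay, with a stated time of 72 h; on this read-out lower numbers stand for stronger inhibition and higher numbers for weaker inhibition:
- compound 1 `O=C(CN1CCN(C(=O)c2ccc(F)cc2)CC1)N1CCN(CCCc2c[nH]c3ccc(F)cc23)CC1` gives 102000 nM
- compound 2 `O=C(CN1CCN(C(=O)c2cccc(Br)c2)CC1)N1CCN(CCCc2c[nH]c3ccc(F)cc23)CC1` gives 40600 nM
- compound 3 `O=C(CN1CCN(C(=O)c2cccc(F)c2)CC1)N1CCN(CCCc2c[nH]c3ccc(F)cc23)CC1` gives 83000 nM

Compound 1 stands at the high end of these numbers, together with compound 3 (a 1.2-fold lower number from compound 1 to compound 3 (0.09 log units; within the scatter)), while compound 2 has a lower number (a 2.5-fold lower number from compound 1 to compound 2 (0.40 log units; beyond the scatter)). Compound 4 `COc1ccc2[nH]cc(CCCN3CCN(C(=O)CN4CCN(C(=O)c5ccc(F)cc5)CC4)CC3)c2c1` keeps the rest of compound 1 but carries methoxy in place of fluoro on an aromatic carbon, turning 5-fluoro-1H-indol-3-yl into 5-methoxy-1H-indol-3-yl (methoxy in place of fluoro on an aromatic carbon). Among the compounds with values here, no measured step touches this site. All three concern the aromatic ring on the carbonyl carbon at the other end of the molecule, the remaining one being a 2.0-fold higher number from compound 2 to compound 3 (0.31 log units; beyond the scatter). These steps offer only a rough scale for the change. Taking the largest of them (a 2.5-fold lower number from compound 1 to compound 2 (0.40 log units; beyond the scatter)) as that scale, no more than a modest step is expected in this assay, and its direction remains open. The expected step is small (a 1.2-fold lower number from compound 1 to compound 4 (0.08 log units; within the scatter)). For compound 4 the estimated value is 85000 nM, with an expected range from 35000 nM to 200000 nM.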

Compound 4, half-maximal inhibitory concentration: > 200000 nM
Compound 4: only a limit was reported; the forecaster's own chance of this, stated with the estimate: 15%; at least 2.3-fold (0.37 log units) between middle value and limit.
By their numbers in this assay, from the lowest: compound 2; then compounds 3 and 1 (each within the scatter of the next). At a limit, above all of these: compound 4.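

Compound 4 alone among the compounds shown changes the 5-fluoro-1H-indol-3-yl group, and in this assay its reading is a limit and not a number: the limit of > 200000 nM in this assay, at which 1 of the 4 values shown sits.

Methoxy in place of fluoro at this site gives an at least 1.9-fold higher number from compound 1 to compound 4 (0.29 log units; that floor lies within the scatter), so this change brings no lower number, although the floor of the step does not clear the usual scatter. Within the data shown here, how far the true value lies past that floor remains unknown, and the earlier steps, all on the aromatic ring on the carbonyl carbon, gave no reading of this position.

The compounds shown leave open how a hydroxy group, a chloro group or a longer ethoxy chain would read at this place. They also leave open whether methoxy would give the same result alongside the 3-bromophenyl group of compound 2.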